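The source may hold more compounds than are shown below. What is called first, only, known or untested is meant among the compounds shown, and "the series" means these compounds.

In a functional assay on Jurkat cells (Homo sapiens) for inhibition (on this read-out lower numbers stand for stronger inhibition and higher numbers for weaker inhibition), the three measured compounds share one core and differ only in the group on the saturated carbon bound to the carbonyl. Compound 1 `CC(C)[C@H](NC(=O)COc1cccc2ccccc12)C(=O)N[C@@H](CC(=O)O)C(=O)COc1cc(C(F)(F)F)n(C)n1` gives 46000 nM. Compound 2 `CC(C)[C@H](NC(=O)COc1cccc2ccccc12)C(=O)N[C@@H](CC(=O)O)C(=O)CSc1nncn1C` gives only a limit of the assay, > 200000 nM. Compound 3 `CC(C)[C@H](NC(=O)COc1cccc2ccccc12)C(=O)N[C@@H](CC(=O)O)C(=O)COc1cc(C(F)(F)F)ncn1` likewise gives only a limit, > 200000 nM. Compound 3 therefore stands at the weak end of what is shown, at the limit of > 200000 nM in this assay, at which 2 of the 3 values shown sit. The step of an at least 4.3-fold higher number from compound 1 to compound 3 (0.63 log units; beyond the scatter) is the only one of readable size that touches compound 3, while the step that the two limits leave unreadable from compound 2 to compound 3 cannot be read. Compound 4 `CC(C)[C@H](NC(=O)COc1cccc2ccccc12)C(=O)N[C@@H](CC(=O)O)C(=O)COc1cc2ccccc2cn1` carries isoquinolin-3-yl in place of 6-(trifluoromethyl)pyrimidin-4-yl on an oxygen on a saturated carbon. Going by the values given here, no measured step exchanges a 6-(trifluoromethyl)pyrimidin-4-yl for an isoquinolin-3-yl, so the expectation rests on compound 3 alone, whose value is a limit and leaves only a downward direction readable. The estimated step of an at least 1.3-fold lower number from compound 3 to compound 4 (0.12 log units; that floor lies within the scatter) is accordingly modest. Compound 4 is expected to give about 150000 nM, within 30000 nM to 600000 nM.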

Compound 4, half-maximal inhibitory concentration: > 200000 nM
Compound 4 ended at the assay's limit (the forecaster's own chance of this, stated with the estimate: 40%); at least 1.3-fold (0.12 log units) between middle value and limit.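

In this assay compound 4 gives > 200000 nM, which is a limit of the assay and not a number. Isoquinolin-3-yl, which carries no fluorine, thus joins 6-(trifluoromethyl)pyrimidin-4-yl at the weak end, and the step of an at least 4.3-fold higher number from compound 1 to compound 4 (0.63 log units; beyond the scatter) leaves the 1-methyl-5-(trifluoromethyl)-1H-pyrazol-3-yl of compound 1 as the only group on this oxygen with a readable value. The steps from compound 2 and compound 3 to compound 4 cannot be read, and the series now collects at one end: the limit of > 200000 nM in this assay, at which 3 of the 4 values shown sit.

As far as these compounds go, how far compound 2, compound 3 and compound 4 differ from one another remains open. Also open, from the compounds shown here alone, is whether the trifluoromethyl or the methyl on the pyrazole of compound 1 matters, which a plain 1H-pyrazol-3-yl on the same oxygen would help to settle.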